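A longer chain on compound 1

The source may hold more compounds than are shown below. What is called first, only, known or untested is meant among the compounds shown, and "the series" means these compounds.

In a functional assay on MDA-MB-231 cells (Homo sapiens) for cytotoxicity, read by MTT assay, with a stated time of 24 h (a lower number here means a stronger inhibitor, a higher number a weaker inhibitor), compound 1 (`CCCCCC(=O)Nc1nnc(S[C@@H]2O[C@H](CO)[C@H](O)[C@H](O)[C@H]2O)s1`) gives 28700 nM and sits within the scatter of compound 2 (`CCCCCCCC/C=C\CCCCCCCCCCCC(=O)Nc1nnc(S[C@@H]2O[C@H](COC(C)=O)[C@H](OC(C)=O)[C@H](OC(C)=O)[C@H]2OC(C)=O)s1`) at 25300 nM and of compound 3 (`CCCCCCCCCC(=O)Nc1nnc(S[C@@H]2O[C@H](COC(C)=O)[C@H](OC(C)=O)[C@H](OC(C)=O)[C@H]2OC(C)=O)s1`) at 19200 nM as well. Compound 4 (`C=CCCCCCCCCC(=O)Nc1nnc(S[C@@H]2O[C@H](CO)[C@H](O)[C@H](O)[C@H]2O)s1`) carries pent-4-en-1-yl in place of hydrogen on a saturated chain carbon, five bonds along the chain from a carbonyl carbon. Among the compounds with values here, the only measured step that alters a chain is a 1.3-fold lower number from compound 2 to compound 3 (0.12 log units; within the scatter) and it stays within the scatter, though it was seen on a core that differs from that of compound 1. The estimated step is therefore a 1.3-fold lower number from compound 1 to compound 4 (0.12 log units; within the scatter) in this assay and nothing beyond the scatter is expected. Compound 4 is expected at 22000 nM with a range from 10000 nM to 45000 nM as the estimated span.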

Compound 4, half-maximal inhibitory concentration: 80600 nM
Beside the measured number, compound 4's estimate is 3.7-fold (0.56 log units) below it, outside the stated range (above it).
By their numbers in this assay, from the lowest: compounds 3, 2 and 1 (each within the scatter of the next); then compound 4.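

In this assay, placing pent-4-en-1-yl on the saturated chain carbon five bonds along the chain from the carbonyl carbon gives a 2.8-fold higher number from compound 1 to compound 4 (0.45 log units; beyond the scatter), so a longer chain on the core of compound 1 goes with a weaker inhibitor. Within the data shown here, the only earlier chain change, on a different core, stayed within the scatter, at a 1.3-fold lower number from compound 2 to compound 3 (0.12 log units; within the scatter). Nothing shown gives a reason for the new step. On these data alone, what remains open is whether the added length or the double bond goes with this step, which pentyl in place of pent-4-en-1-yl would separate, and whether pent-4-en-1-yl has the same effect on the core of compound 2.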